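The source may report more compounds than this note shows. Statements on the series, on what has been measured and on what is new or still open speak of the compounds shown alone.

Of the compounds shown here, three built on a shared core have been tested in a functional assay on MCF7 cells (Homo sapiens) for antiproliferative activity, read by MTT assay, with a stated time of 48 h (on this read-out higher numbers stand for weaker inhibition and lower numbers for stronger inhibition), and a fourth awaits testing. Compound 1, `O=C(/C=C/c1cc(Cl)cc(Cl)c1Oc1c([N+](=O)[O-])cc(C(F)(F)F)cc1[N+](=O)[O-])c1ccc(Cl)cc1`, gives 4.54 ug/mL. Compound 2, `O=C(/C=C/c1cccc(Br)c1Oc1c([N+](=O)[O-])cc(C(F)(F)F)cc1[N+](=O)[O-])c1ccc(Cl)cc1`, gives 4.74 ug/mL. Compound 3, `O=C(/C=C/c1cccc(Cl)c1Oc1c([N+](=O)[O-])cc(C(F)(F)F)cc1[N+](=O)[O-])c1ccc(Cl)cc1`, gives 3.21 ug/mL. Compound 4, `O=C(/C=C/c1cc(Cl)cc(Cl)c1Oc1c([N+](=O)[O-])cc(C(F)(F)F)cc1[N+](=O)[O-])c1ccc(Br)cc1`, has not yet been measured in this assay.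

The cores of compound 1 and compound 3 differ by chloro in place of hydrogen on an aromatic carbon, and the step of a 1.4-fold lower number from compound 1 to compound 3 (0.15 log units; within the scatter) stays small. Compound 2 differs from compound 3 by bromo in place of chloro on an aromatic carbon, which gave the step of a 1.5-fold higher number from compound 3 to compound 2 (0.17 log units; within the scatter). Compound 4 differs from compound 1 by bromo in place of chloro on an aromatic carbon. This is the same kind of change, but not the same: in compound 2 it sits ortho to a large group and meta to a 2-((4-chlorophenyl)carbonyl)ethenyl group, whereas in compound 4 it sits para to a large group.

Because the earlier step of a 1.5-fold higher number from compound 3 to compound 2 (0.17 log units; within the scatter) stayed within the scatter, the step from compound 1 to compound 4 is expected to be of similar size, namely a 1.1-fold higher number from compound 1 to compound 4 (0.03 log units; within the scatter). Compound 4 is therefore estimated to give about 4.9 ug/mL, with a likely range from 2.8 ug/mL to 8.5 ug/mL.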

Compound 4, half-maximal inhibitory concentration: 2.6 ug/mL
Compound 4: middle estimate off by 1.9-fold (0.28 log units), on the high side; measured number outside the range, below it.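

In this assay, bromo in place of chloro on the 4-chlorophenyl group gave a 1.7-fold lower number from compound 1 to compound 4 (0.24 log units; within the scatter). Set beside the earlier exchange of the same kind on a different core and at a different place, this step cannot be told apart from it: the same change on two cores in this assay, a 1.5-fold higher number (0.17 log units; within the scatter) from compound 3 to compound 2 and a 1.7-fold lower number (0.24 log units; within the scatter) from compound 1 to compound 4, 2.6-fold (0.41 log units) apart, within the scatter of two such steps The series therefore gives no sign that this exchange behaves differently from one core to the other, but it does not show that the result carries over, since each core offers only one pair and neither step leaves the scatter.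

The compounds shown carry only hydrogen, chloro or bromo at the varied aromatic carbons, so the effect of an amine, a methoxy group or a carboxylic acid at those places remains open. Also open, from the compounds shown here alone, is how the read-out would respond if the 2-((4-bromophenyl)carbonyl)ethenyl group were replaced by a longer chain.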